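The compounds below may be only part of what the source reports. "The series", "measured", "known", "first", "only" and "open" are said of these compounds alone.

Working notes on the series in an ADME assay on microsomes from liver (Homo sapiens) for metabolic stability, read by LC-MS, using NADPH, with stated times of 10 min and 45 min, tested at 1 uM; on this read-out lower numbers stand for slow clearance and higher numbers for fast clearance.

Three compounds carry results. Going by the values given here, compound 1 `Cc1cc(C)c(CN2CCc3c(Cl)cc([C@@H](CO)[C@@H]4CCOC4)c(Cl)c3C2=O)c(=O)[nH]1` gives 25.3 uL/min and is the only compound with a single plain number. Compound 2 `COC(c1cc(Cl)c2c(c1Cl)C(=O)N(Cc1c(C)cc(C)[nH]c1=O)CC2)C1CCN(C2COC2)CC1` gives 78.3 uL/min; 72.7 uL/min (2 entries), with the several entries of compound 2 in this assay, 78.3 uL/min; 72.7 uL/min (2 entries) lying close together. Compound 3 `COc1cc(C)[nH]c(=O)c1CN1CCc2c(Cl)cc([C@@H](O)C3COC3)c(Cl)c2C1=O` returns < 7 uL/min, which is a limit of the assay and not a number, as the limit of < 7 uL/min in this assay, at which 1 of the 3 values shown sits, records. On what is shown, compound 1 therefore stands in the middle of the three results: clearly under the two entries of compound 2 and above the limit reached by compound 3.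

Compound 4 `Cc1cc(C)c(CN2CCc3c(Cl)cc([C@H](CO)[C@H]4CCOC4)c(Cl)c3C2=O)c(=O)[nH]1` is the next case. Relative to compound 1, (the two compounds have the same atoms and bonds and differ only in configuration as drawn: 2 of 2 stereo elements differ (all stereocentres are inverted: mirror images); a stereocentre at a saturated chain carbon is drawn S in compound 1 and R in compound 4; a stereocentre at a saturated ring carbon is drawn S in compound 1 and R in compound 4). Among the compounds with values here, no measured pair in the set differs in exactly this way, so there is no comparison to lean on. For a change that alters only the drawn configuration, the working expectation is a step of no particular direction and of a size that stays within the usual scatter, so that the two compounds read much alike. The step from compound 1 to compound 4 is estimated as a 1.0-fold lower number from compound 1 to compound 4 (0.01 log units; within the scatter). Within the data shown here, compound 4 is accordingly expected to give 25 uL/min, with a likely range from 11 uL/min to 55 uL/min, the width reflecting that no stereo pair in the set has yet been measured.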

Compound 4, intrinsic clearance in a liver preparation (reported as CLH), per the amount of preparation that the assay uses: 21.3 uL/min
The estimate for compound 4 lay 1.2-fold (0.07 log units) above the measured number, and the stated range covers the measured number.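

The series now holds its first pair that differs only in configuration as drawn, and in this assay the step is a 1.2-fold lower number from compound 1 to compound 4 (0.07 log units; within the scatter). Inverting both the stereocentre at the saturated chain carbon and the one at the saturated ring carbon therefore leaves the two mirror images reading alike, something that compounds 1, 2 and 3 could not show on their own, as no two of them differ in this way alone. The comparison is a clean one, with no change in atoms or bonds to confuse it: the fact that compounds 1 and 4 differ only in the configuration as drawn

From the compounds shown here alone, whether inverting only one of the two stereocentres would read the same stays open, as the inversion here covers both at once and a single pair cannot separate their contributions. Also open, going by these compounds, is whether this indifference to configuration in this assay would persist with another group at the saturated chain carbon, such as a carboxylic acid or an amine, or with a piperidine at the saturated ring carbon in place of the ring carried by compound 1.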